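The compounds below may be only part of what the source reports. "The series", "measured", "known", "first", "only" and "open" are said of these compounds alone.

Compound 1 `COc1cc2nc(N3CCN(C(=O)OCc4ccccc4)CC3)nc(N)c2cc1OC` — 63000 nM
Compound 2 `COc1ccc(C(=O)N2CCN(c3nc(N)c4cc(OC)c(OC)cc4n3)CC2)cc1OC` — 71000 nM
Compound 3 `COc1cc2nc(N3CCN(S(=O)(=O)c4ccc(C(F)(F)F)cc4)CC3)nc(N)c2cc1OC` — 27000 nM

The three measured compounds share a core and differ only in the group attached to the piperazine nitrogen. In a functional assay on PC-3 cells (Homo sapiens) for inhibition (a higher number here means a weaker inhibitor, a lower number a stronger inhibitor), compound 1 gives 63000 nM and compound 2 gives 71000 nM; the change a 1.1-fold higher number from compound 1 to compound 2 (0.05 log units; within the scatter) is small. Compound 3, carrying a sulfonyl linkage, gives 27000 nM and thus has the lowest number of the three, beyond the scatter relative to both compound 1 and compound 2.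

Compound 4 `COc1cc2nc(N3CCN(S(=O)(=O)c4cc(C(=O)O)c(Cl)cc4Cl)CC3)nc(N)c2cc1OC` has not yet been measured in this assay. It differs from compound 3 as follows: 5-carboxy-2,4-dichlorophenyl in place of 4-(trifluoromethyl)phenyl on a sulfonyl sulfur. Within the data shown here, no measured step alters the group on the sulfonyl sulfur, so nothing here bears directly on this change. Among the measured compounds shown here, the only recorded step, a 1.1-fold higher number from compound 1 to compound 2 (0.05 log units; within the scatter), changes a group on a carbonyl carbon and lies within the scatter, which at least shows that swapping one aryl group for another at that position left the number essentially unchanged. By analogy, the step of a 1.3-fold higher number from compound 3 to compound 4 (0.11 log units; within the scatter) is expected to be modest, without a clear direction. Compound 4 is therefore estimated at 35000 nM, with a range from 12000 nM to 100000 nM.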

Compound 4, half-maximal inhibitory concentration: 52000 nM
For compound 4 the middle estimate is 1.5-fold (0.17 log units) below the measured one, within the range that was stated.
By their numbers in this assay, from the lowest: compounds 3, 4, 1 and 2 (each within the scatter of the next, the first and the last beyond it).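

In this assay, among these compounds, the step of a 1.9-fold higher number from compound 3 to compound 4 (0.28 log units; within the scatter) is the first reading of a change on the sulfonyl sulfur, where the earlier compounds offered only a step on a carbonyl carbon. At this position, then, 5-carboxy-2,4-dichlorophenyl and 4-(trifluoromethyl)phenyl cannot be told apart in this read-out, even though the entering group counts 1 hydrogen-bond donor and 1 hydrogen-bond acceptor and the leaving group 0 of each. Nothing available explains this outcome or says how these groups act on the cells.

As far as these compounds go, the entering group differs from the leaving one in its carboxy group and its two chlorines at once, and the trifluoromethyl group is lost in the same step, so what each of these contributes stays open; a dichlorophenyl group without the carboxy, or a plain phenyl, on the sulfonyl sulfur would separate them. Also open, from the compounds shown here alone, is whether anything other than a substituted phenyl at this place, such as a methyl group or a longer alkyl chain, or a phenyl carrying an amine, would give a number beyond the scatter.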